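Stereochemical inversion at a saturated ring carbon

The source may hold more compounds than are shown below. What is called first, only, known or untested is meant among the compounds shown, and "the series" means these compounds.

Measured compounds:
compound 1, `CN1CCN(c2ccc(Nc3ncc4nc(Nc5ccc(F)cc5)n([C@H]5CCNC5)c4n3)cc2)CC1`, "not determined" (no result reported)
compound 2, `CN1CCN(c2ccc(Nc3ncc4nc(Nc5ccc(F)cc5)n([C@H]5CCCN(S(=O)(=O)C6CC6)C5)c4n3)cc2)CC1`, 1340 nM
compound 3, `CN1CCN(c2ccc(Nc3ncc4nc(Nc5ccc(F)cc5)n([C@@H]5CCCN(C(=O)CO)C5)c4n3)cc2)CC1`, "not determined" (no result reported)

Not yet measured: compound 4, `CN1CCN(c2ccc(Nc3ncc4nc(Nc5ccc(F)cc5)n([C@H]5CCCN(C(=O)CO)C5)c4n3)cc2)CC1`.

In a functional assay on A-431 cells (Homo sapiens) for antiproliferative activity, read by MTT assay, with a stated time of 72 h (on this read-out lower numbers stand for stronger inhibition and higher numbers for weaker inhibition), compound 2 gives 1340 nM. In this assay compound 3 gives "not determined" (no result reported), so no number for compound 3 is known, and compound 1 likewise gives "not determined" (no result reported) in this assay. Compound 3 therefore stands nowhere on the numbers shown; the single measured value in this set belongs to compound 2.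

The step from compound 3 to compound 4 is described by the two compounds have the same atoms and bonds and differ only in configuration as drawn: 1 of 1 stereo elements differ; a stereocentre at a saturated ring carbon is drawn R in compound 3 and S in compound 4. Because compound 3 carries no value in this assay, the size of this step cannot be read from the data, and no direction can be assigned beyond what compound 2 shows for the shared core. Compound 4 shares the drawn configuration at the saturated ring carbon with compound 2, which gives 1340 nM in this assay. On that basis compound 4 is expected to give 1000 nM in this assay, with a range from 300 nM to 4000 nM.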

Compound 4, half-maximal inhibitory concentration: 3000 nM
Estimate against measurement, compound 4: 3.0-fold (0.48 log units) below, within the range that was stated.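

In this assay, with the saturated ring carbon drawn the same way in both compounds, placing (hydroxymethyl)carbonyl instead of cyclopropylsulfonyl on the amine nitrogen in a ring gives a 2.2-fold higher number from compound 2 to compound 4 (0.35 log units; beyond the scatter). The group on this nitrogen therefore shifts the number, and (hydroxymethyl)carbonyl now has a value at this position, though only with the ring carbon drawn S. The step across the inversion cannot be read, and the one firm statement about that pair is structural: the fact that compounds 3 and 4 differ only in the configuration as drawn

From the compounds shown here alone, whether drawing the ring carbon R raises or lowers the number remains open. So does the question of where an acetyl group, or a longer chain ending in a carboxylic acid, on the same nitrogen would fall relative to compound 2 and compound 4.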